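The compounds below may be only part of what the source reports. "The series", "measured", "known", "first", "only" and "open" are said of these compounds alone.

Measured compounds:
Compound 1 `COc1ccccc1CN1CCC=C(CCC(=O)NO)C1=O`: > 10000 nM (a limit of the assay)
Compound 2 `Cc1cccc(CN2CCC=C(CCC(=O)NO)C2=O)c1`: 8120 nM

Within the data shown here, in a functional assay on MDA-MB-231 cells (Homo sapiens) for inhibition, read by sulforhodamine B assay (on this read-out higher numbers stand for weaker inhibition of growth and lower numbers for stronger inhibition of growth), compound 2 gives 8120 nM, the only actual number available so far. Compound 1 is reported only as a limit of the assay, > 10000 nM. Among the measured compounds shown here, no measured step links two compounds in this set, which leaves compound 2 as the single numerical reference point.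

The next compound to be tested is compound 3 `Cc1ccccc1CN1CCC=C(CCC(=O)NO)C1=O`, which keeps the rest of compound 2 unchanged. It carries 2-methylphenyl in place of 3-methylphenyl on a saturated chain carbon bound to an amide-type nitrogen in a ring. The two compounds have the same atoms, joined differently.

For the measured compounds named here, with no measured step to scale this change, no shift beyond the usual scatter is expected in this assay, and neither direction is favoured. The expectation rests on compound 2 at 8120 nM. The estimated change is small, a 1.1-fold higher number from compound 2 to compound 3 (0.04 log units; within the scatter). For compound 3 the expected value is 9000 nM, within an estimated range of 4000 nM to 20000 nM.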

Compound 3, concentration for 50% growth inhibition: 4920 nM
Compound 3: middle estimate off by 1.8-fold (0.26 log units), on the high side, and the stated range covers the measured number.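

In this assay, exchanging 3-methylphenyl for 2-methylphenyl on a saturated chain carbon bound to an amide-type nitrogen in a ring gives a 1.7-fold lower number from compound 2 to compound 3 (0.22 log units; within the scatter), so the two isomers cannot be told apart on this read-out. Among these compounds, compound 3 also provides the first comparison of methyl and methoxy on an aromatic carbon, with an at least 2.0-fold lower number from compound 1 to compound 3 (0.30 log units; that floor lies within the scatter), and that figure is only a floor. Compound 1 is reported as a limit of the assay, so the full size of this step remains unknown: the limit of > 10000 nM in this assay, at which 1 of the 3 values shown sits.

The compounds shown leave open how 4-methylphenyl, or a phenyl group carrying an amine or a carboxylic acid in place of the methyl, would read at this same place in this assay. They also leave open whether a longer chain between the amide-type nitrogen and the phenyl group would produce a step beyond the scatter, which neither of the steps here does.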